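Fluoro in place of nitro on the para-substituted phenyl ring

The source may report more compounds than this note shows. Statements on the series, on what has been measured and on what is new or still open speak of the compounds shown alone.

Compound 2, `CC(C)Cc1ccc(C(C)c2nn(CN3CCN(c4ccc([N+](=O)[O-])cc4)CC3)c(=S)o2)cc1`, gives 30.6% in a functional assay on the whole organism (strain Swiss albino) for inhibition, with Mus musculus as the target, in the hot plate test, with stated times of 15 s and 30 min, at a dose of 10 mg/kg by the oral route; on this read-out higher numbers stand for more inhibition at the one dose given (going by the name of the read-out) and lower numbers for less inhibition. Compound 1, `CC(C)Cc1ccc(C(C)c2nn(CN3CCN(c4ccc(Cl)cc4)CC3)c(=S)o2)cc1`, gives 22.8% in the same assay, so the two values lie within the scatter of each other, and the two numbers count as level. For the measured compounds named here, the step between them, a number 7.8 percentage points higher from compound 1 to compound 2 (within the scatter), is the only measured change at this place, and it did not move the read-out beyond the scatter. Compound 3, `CC(C)Cc1ccc(C(C)c2nn(CN3CCN(c4ccc(F)cc4)CC3)c(=S)o2)cc1`, differs from compound 2 by fluoro in place of nitro on an aromatic carbon. Since the exchange of chloro for nitro at this carbon left the number essentially unchanged, a halogen in this place is expected to give a value close to that of compound 2, with no step beyond the scatter; the step expected is a number 6.6 percentage points lower from compound 2 to compound 3 (within the scatter). Compound 3 is therefore estimated at 24%, with a likely range from 12% to 36%.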

Compound 3, a percentage reported as inhibition, in the whole organism at one dose (the size of the read-out at that dose, not a potency): 32.6%
Estimate against measurement, compound 3: 8.6 percentage points below; low and high end bracket the measured number.
By their numbers in this assay, from the lowest: compounds 1, 2 and 3 (each within the scatter of the next).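

With fluoro in place of nitro on the aromatic carbon para to a large group, one heavy atom stands where there were three, and no hydrogen-bond acceptor where there were two, yet this assay shows a number 2 percentage points higher from compound 2 to compound 3 (within the scatter). The halogen exchange reads the same way, with a number 9.8 percentage points higher from compound 1 to compound 3 (within the scatter), so chloro, nitro and fluoro at this place all lie within the scatter of one another, and the read-out does not separate these three groups. Nothing available accounts for this level reading.

As far as these compounds go, whether an amine, a methoxy group or a carboxylic acid on this same carbon would also stay level remains open. So does the effect of a hydrogen there, with the ring left bare at this place.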